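Amide swap: piperidin-1-yl to 4-methylpiperazin-1-yl

The compounds below may be only part of what the source reports. "The series", "measured", "known", "first", "only" and "open" are said of these compounds alone.

Measured so far:
compound 1, `O=C(NC1CCCCC1)c1ccc(C#Cc2ccccc2)nc1`, 240 nM
compound 2, `O=C(c1ccc(C#Cc2ccccc2)nc1)N1CCCCC1`, 280 nM

In a functional assay on BHK cells for positive allosteric modulation of metabotropic glutamate receptor 5 (Homo sapiens), read by FLIPR and calcium flux (on this read-out higher numbers stand for an effect only at larger amounts of compound and lower numbers for an effect already at smaller amounts), compound 1 gives 240 nM. Compound 2 gives 280 nM. Compound 2 thus holds the higher of the two numbers, but the step of a 1.2-fold higher number from compound 1 to compound 2 (0.07 log units; within the scatter) is within the scatter, so the two compounds cannot be told apart on these data.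

Compound 3, `CN1CCN(C(=O)c2ccc(C#Cc3ccccc3)nc2)CC1`, has not yet been measured. It differs from compound 2 by 4-methylpiperazin-1-yl in place of piperidin-1-yl on a carbonyl carbon. Among the compounds with values here, only one measured step exists, and it is of a different kind: a 1.2-fold higher number from compound 1 to compound 2 (0.07 log units; within the scatter) changed the substituent on the carbonyl carbon and left the number where it was. Within the data shown here, no measured step introduces a second ring nitrogen or a hydrogen-bond acceptor at this place, so the basis for prediction is thin. Given that the one change at the carbonyl carbon was without effect beyond the scatter, compound 3 is expected to land near compound 2. The expected step of a 1.4-fold higher number from compound 2 to compound 3 (0.15 log units; within the scatter) is small. Compound 3 is estimated at 400 nM, with a range from 150 nM to 1200 nM.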

Compound 3, half-maximal effective concentration: 1600 nM
For compound 3 the middle estimate is 4.0-fold (0.60 log units) below the measured one; the whole stated range lies below it.
By their numbers in this assay, from the lowest: compounds 1 and 2 (each within the scatter of the next); then compound 3.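

In this assay the group on the carbonyl carbon now proves able to move the number: 4-methylpiperazin-1-yl in place of piperidin-1-yl gives a 5.7-fold higher number from compound 2 to compound 3 (0.76 log units; beyond the scatter) whereas the earlier change at this place, a 1.2-fold higher number from compound 1 to compound 2 (0.07 log units; within the scatter) in the same terms, left the two compounds indistinguishable. Measured against the cyclohexylamino amide, the same group gives a 6.7-fold higher number from compound 1 to compound 3 (0.82 log units; beyond the scatter) so compound 3 stands apart from both earlier compounds by a step of similar size, and the result does not depend on which of them serves as the reference. This place on the shared core therefore accepts cyclohexylamino and piperidin-1-yl alike, but among these three compounds it does not accept 4-methylpiperazin-1-yl equally well, the one group here with a second ring nitrogen and a hydrogen-bond acceptor.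

That group differs from piperidin-1-yl in two ways at once, so the compounds shown cannot separate the ring nitrogen from its methyl, which an unsubstituted piperazin-1-yl, a morpholin-4-yl or a 4-methylpiperidin-1-yl amide could begin to do. Nothing available explains why the number rises with this change.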